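The compounds below may be only part of what the source reports. "The series", "measured", "known", "first", "only" and "open" are said of these compounds alone.

Within the data shown here, in a functional assay on A-375 cells (Homo sapiens) for antiproliferative activity, read by MTT assay, with a stated time of 48 h (on this read-out lower numbers stand for stronger inhibition of growth and higher numbers for weaker inhibition of growth), compound 2 `Fc1ccc(C2=NN(C(=S)Nc3ccccc3)C(c3ccc4c(c3)OCCO4)C2)cc1` gives 15700 nM, the second highest of the three numbers known so far. Its nearest neighbour is compound 1 `S=C(Nc1ccccc1)N1N=C(c2ccccc2)CC1c1ccc2c(c1)OCCO2`, which gives 1850 nM; the step between them is an 8.5-fold higher number from compound 1 to compound 2 (0.93 log units; beyond the scatter). Furthest away is compound 3 `S=C(Nc1ccccc1)N1N=C(c2ccc(Cl)cc2)CC1c1ccc2c(c1)OCCO2`, which gives 195000 nM, reached by a 12-fold higher number from compound 2 to compound 3 (1.09 log units; beyond the scatter). The third measured step, a 110-fold higher number from compound 1 to compound 3 (2.02 log units; beyond the scatter), runs from the compound without a halogen straight to the chloro compound. Compound 4 `S=C(Nc1ccccc1)N1N=C(c2ccc(Br)cc2)CC1c1ccc2c(c1)OCCO2` has not yet been measured. It differs from compound 2 by bromo in place of fluoro on an aromatic carbon. Both halogen steps already seen run the same way: putting fluoro in place of hydrogen weakened growth inhibition modestly, and putting chloro in place of fluoro weakened it further by a large step. Among the measured compounds shown here, only three compounds support this reading, so it rests on a narrow base. Still, because a 12-fold higher number from compound 2 to compound 3 (1.09 log units; beyond the scatter) was large, a further large step in the same direction is expected for compound 4 in this assay, of about a 13-fold higher number from compound 2 to compound 4 (1.11 log units; beyond the scatter). Compound 4 is therefore estimated at 200000 nM, most likely between 40000 nM and 1000000 nM.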

Compound 4, concentration for 50% growth inhibition: 470 nM
Compound 4: middle estimate off by 430-fold (2.63 log units), on the high side; measured number outside the range, below it.
By their numbers in this assay, from the lowest: compound 4; then compound 1; then compound 2; then compound 3.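

In this assay, this position does not follow one trend across the halogens: the rise in the number seen with fluoro and chloro reverses with bromo, giving (a 33-fold lower number from compound 2 to compound 4 (1.52 log units; beyond the scatter)) and (a 410-fold lower number from compound 3 to compound 4 (2.62 log units; beyond the scatter)). Bromo is also the only halogen shown that improves on hydrogen, with (a 3.9-fold lower number from compound 1 to compound 4 (0.60 log units; beyond the scatter)), whereas compound 2 and compound 3 go against this direction, since both give higher numbers than compound 1. Swapping one halogen for another at this single place can therefore change growth inhibition greatly, and the result for one halogen does not predict the next.

Nothing shown here explains why bromo and chloro part so sharply. As far as these compounds go, whether iodo, methyl, methoxy or nitrile at the same place would give a number closer to that of compound 4 or compound 3 remains open.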